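Swapping chloro for fluoro in compound 2

The source may hold more compounds than are shown below. What is called first, only, known or untested is meant among the compounds shown, and "the series" means these compounds.

Compound 1 `Cc1c(C(C)c2c(F)cccc2Cl)nc(SC(C)C)[nH]c1=O`: > 15000 nM
Compound 2 `CCC(c1nc(SC(C)C)[nH]c(=O)c1C)c1c(F)cccc1Cl`: > 3000 nM

In an ADME assay on MT4 cells (Homo sapiens) for activation, read by MTT assay (a higher number here means that more compound is tolerated, a lower number that less compound is tolerated), compound 1 gives only a limit, > 15000 nM. From the compounds shown here alone, compound 2 also gives only a limit, > 3000 nM, so its true value is unknown. Compound 3 `CCC(c1nc(SC(C)C)[nH]c(=O)c1C)c1c(F)cccc1F` puts fluoro in place of chloro on an aromatic carbon. Going by the values given here, the only measured step, a step that the two limits leave unreadable from compound 1 to compound 2, lies at a different place and shows no usable size or direction. Only a small change is therefore expected in this assay, and its direction is uncertain. The expected step is a step that the limit leaves unreadable from compound 2 to compound 3. Compound 3 is estimated at 8000 nM, with an expected range of 3000 nM to 40000 nM.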

Compound 3, half-maximal cytotoxic concentration: > 30000 nM
Compound 3 gave a limit, no number; the forecaster's own chance of this, stated with the estimate: 75%; middle value at least 3.7-fold (0.57 log units) away from the limit.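

Compound 2 and compound 3 each give only a limit in this assay, so no step can be read from fluoro in place of chloro. The compounds shown leave open whether that swap changes tolerated concentration at all.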